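Trimming the amino substituent to methyl on a fluorobenzyl core

This account rests on a few compounds, and the source may have more. Where it says the series, first, only, none or still open, it means among the compounds named here.

Measured so far:
compound 1, `CNc1nc(-c2ccccc2)nc2c1nnn2Cc1ccccc1Cl`, 191000000 nM
compound 2, `Fc1ccccc1Cn1nnc2c(NC3CCCCC3)nc(-c3ccccc3)nc21`, 1150000 nM
compound 3, `CC(O)CNc1nc(-c2ccccc2)nc2c1nnn2Cc1ccccc1F`, 4800000 nM

In an assay on isolated protein for binding affinity to adenosine receptor A1 (Bos taurus) (a higher number here means a weaker inhibitor, a lower number a stronger inhibitor), compound 3 stands second highest of the three numbers; its nearest neighbour is compound 2, whose number is lower, and its furthest is compound 1, whose number is higher. Compound 4, `CNc1nc(-c2ccccc2)nc2c1nnn2Cc1ccccc1F`, has not yet been measured. The change from compound 3 to compound 4 is hydrogen in place of 1-hydroxyethyl on a saturated chain carbon bound to a nitrogen on an aromatic ring. Among the measured compounds shown here, one measured step bears on this change: the step of a 4.2-fold higher number from compound 2 to compound 3 (0.62 log units; beyond the scatter) showed that replacing the cyclohexyl group with a smaller 2-hydroxypropyl group raised the number. Compound 4 goes further, to methylamino. For the measured compounds named here, compound 1 also carries methylamino, with a chlorobenzyl group in place of the fluorobenzyl group, and its value in this assay is the highest of the three; no single step links it to compound 4, so only its value is of note. On this basis compound 4 is expected to bind more weakly than compound 3, with an expected step of a 10-fold higher number from compound 3 to compound 4 (1.02 log units; beyond the scatter). The estimate for compound 4 is 50000000 nM, expected to lie between 10000000 nM and 300000000 nM.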

Compound 4, inhibition constant: 25000000 nM
Compound 4: the middle estimate sits 2.0-fold (0.30 log units) above what was measured; the measured number falls inside the stated range.
By their numbers in this assay, from the lowest: compound 2; then compound 3; then compound 4; then compound 1.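

Across this assay, the step of a 5.2-fold higher number from compound 3 to compound 4 (0.72 log units; beyond the scatter) continues in the direction of a 4.2-fold higher number from compound 2 to compound 3 (0.62 log units; beyond the scatter), so the number rises in the order cyclohexyl, 2-hydroxypropyl, methyl on the nitrogen, with a total span of a 22-fold higher number from compound 2 to compound 4 (1.34 log units; beyond the scatter). Among the compounds shown here, with methylamino held fixed, the aromatic halogen also proves to matter, as fluoro in place of chloro gives a 7.6-fold lower number from compound 1 to compound 4 (0.88 log units; beyond the scatter), a change that no earlier pair could isolate. No available evidence accounts for either trend.

The compounds shown leave open whether the hydroxy group of compound 3 contributes separately from chain length, which a plain propyl chain on the nitrogen would address. They also leave open whether the halogen step carries over to the cyclohexyl or 2-hydroxypropyl series, and how an unsubstituted benzyl or a bromo group would compare.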